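The compounds below may be only part of what the source reports. "The series", "measured", "known", "first", "only" and "open" are said of these compounds alone.

Measured so far: compound 1 `CCC(C)C(NC(=O)NO)C(=O)NC1CCCCC1` gives 150000 nM in a functional assay on MOLT-4 cells (Homo sapiens) for inhibition; on this read-out higher numbers stand for weaker inhibition and lower numbers for stronger inhibition. Compound 2 `CCC(C)C(NC(=O)n1nnc2ccccc21)C(=O)NC(c1ccccc1)c1ccccc1` gives 79000 nM in this assay. Compound 3 `CC(C)C1NC(=O)N(C2CCCCC2)C1=O` gives > 200000 nM in this assay, which is a limit of the assay and not a number.

The numbers of compound 1 and compound 2 lie within the usual scatter of each other, so neither can be called the stronger inhibitor. For compound 3 only the limit of > 200000 nM in this assay, at which 1 of the 3 values shown sits, is known. Compound 4 `CCC(C)C(NC(=O)NO)C(=O)NC1CCCC1` has not yet been measured. It differs from compound 1 by cyclopentyl in place of cyclohexyl on an amide-type nitrogen. Within the data shown here, no measured pair shows a step of this kind, so no change beyond the scatter is expected in either direction. Compound 4 is therefore expected at about 150000 nM, with a likely range from 60000 nM to 400000 nM. The expected step is no change at the digits printed from compound 1 to compound 4 (within the scatter).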

Compound 4, half-maximal inhibitory concentration: > 100000 nM
Compound 4: no number, only a limit; the forecaster's own chance of this, stated with the estimate: 35%; the middle value is on the limit's open side.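

Among these compounds, compound 4 gives > 100000 nM, which is a limit of the assay and not a number, so no step from compound 1 to compound 4 can be read. On these data alone, whether cyclopentyl in place of cyclohexyl on an amide-type nitrogen changes inhibition in this assay stays open.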